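The compounds below may be only part of what the source reports. "The series", "measured", "known", "first", "only" and "open" are said of these compounds alone.

Compound 1 `COc1ccc(-c2cn3cc(C4=CCN(S(=O)(=O)CCc5ccccc5)CC4)ccc3n2)cc1OC`: 8080 nM
Compound 2 `COc1ccc(-c2cn3cc(C4=CCN(C(=O)c5ccc(Cl)cc5)CC4)ccc3n2)cc1OC`: 15300 nM
Compound 3 `COc1ccc(-c2cn3cc(C4=CCN(C(=O)c5ccccc5)CC4)ccc3n2)cc1OC`: 8370 nM

These three numbers come from a functional assay on B16-F10 cells (Mus musculus) for antiproliferative activity, read by MTT assay, with a stated time of 48 h; on this read-out lower numbers stand for stronger inhibition and higher numbers for weaker inhibition. Compound 2 does not stand apart from the other two, since its value lies within the scatter of both.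

The next structure is compound 4 `COc1ccc(-c2cn3cc(C4=CCN(C(=O)c5cccc(C(F)(F)F)c5)CC4)ccc3n2)cc1OC`, which carries 3-(trifluoromethyl)phenyl in place of 4-chlorophenyl on a carbonyl carbon. Within the data shown here, no measured compound carries a trifluoromethyl group, so the data cannot show directly what this group does.

The closest evidence comes from compound 3, where hydrogen stands in place of chloro on an aromatic carbon: a 1.8-fold lower number from compound 2 to compound 3 (0.26 log units; within the scatter). Larger exchanges on the amine nitrogen in the ring also leave the numbers close. Going to a (4-chlorophenyl)carbonyl group gives a 1.9-fold higher number from compound 1 to compound 2 (0.28 log units; within the scatter), and going to benzoyl gives a 1.0-fold higher number from compound 1 to compound 3 (0.02 log units; within the scatter).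

All three measured steps are small, so no step beyond the scatter is expected in this assay, in either direction. The expected step is a 1.4-fold lower number from compound 2 to compound 4 (0.14 log units; within the scatter), and this is only an estimate. For compound 4 the estimated value is 11000 nM, with an expected range from 5000 nM to 25000 nM.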

Compound 4, half-maximal inhibitory concentration: 7890 nM
The estimate for compound 4 lay 1.4-fold (0.14 log units) above the measured number; the measured number falls inside the stated range.
By their numbers in this assay, from the lowest: compounds 4, 1, 3 and 2 (each within the scatter of the next).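

In this assay, among these compounds, the exchange of 4-chlorophenyl for 3-(trifluoromethyl)phenyl on the carbonyl carbon gives a 1.9-fold lower number from compound 2 to compound 4 (0.29 log units; within the scatter) and the first reading of a trifluoromethyl group at this position, while trifluoromethyl in place of hydrogen on the aromatic carbon gives a 1.1-fold lower number from compound 3 to compound 4 (0.03 log units; within the scatter) and so adds a direct comparison with the plain phenyl. This position therefore accepts a group of 10 heavy atoms in place of one of 7 with no change beyond the scatter, and the same holds for the larger exchange on the ring nitrogen, where a 1.0-fold lower number from compound 1 to compound 4 (0.01 log units; within the scatter) comes with (3-(trifluoromethyl)phenyl)carbonyl in place of phenethylsulfonyl. Every pair among the four compounds now lies within the scatter, and no measurement shown here offers an explanation for this flat picture.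

The compounds shown leave open whether a group of a different kind on this phenyl, such as an amine or a carboxylic acid, would move the number beyond the scatter. They also leave open what a longer chain in place of the phenyl on the carbonyl carbon would do.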